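The source may report more compounds than this note shows. Statements on the series, on what has been measured and on what is new or still open speak of the compounds shown alone.

Compound 3 `COc1ccc(-c2csc(N)c2C(=O)OCc2ccc(C)cc2)cc1OC` stands second highest of the three measured compounds in an assay on isolated protein for inhibition of protein kinase C zeta type (Homo sapiens), with stated times of 1 h and 2.5 min, tested at 30 uM; a higher number here means more inhibition at the concentration tested (going by the name of the read-out), a lower number less inhibition; there compound 3 gives 50%. Compound 1 `CCOC(=O)c1c(-c2ccc(OC)c(OC)c2)csc1N` gives 100%, and compound 2 `COc1ccc(-c2csc(N)c2C(=O)Oc2ccccc2)cc1OC` gives 48%. Compound 4 `COc1ccc(-c2csc(N)c2C(=O)NCc2ccccc2)cc1OC` differs from compound 3 by benzylamino in place of (4-methylbenzyl)oxy on a carbonyl carbon. Among the compounds with values here, two measured steps bear on it only loosely: a number 52 percentage points lower from compound 1 to compound 2 (beyond the scatter) and a number 50 percentage points lower from compound 1 to compound 3 (beyond the scatter) were large, whereas a number 2 percentage points higher from compound 2 to compound 3 (within the scatter) lay within the scatter. Within the data shown here, none of the measured steps replaces the oxygen on the carbonyl carbon with a nitrogen, so the change is untested here. Since the nearest step, a number 2 percentage points higher from compound 2 to compound 3 (within the scatter), gave no shift beyond the scatter, a step of no change at the digits printed from compound 3 to compound 4 (within the scatter) is expected, within the scatter. Compound 4 is therefore estimated at 50%, within a range of 30% to 70%.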

Compound 4, a percentage reported as inhibition, at one concentration (the size of the read-out at that concentration, not a potency): 43%
For compound 4 the middle estimate is 7 percentage points above the measured one; the measured number falls inside the stated range.
By their numbers in this assay, from the lowest: compounds 4, 2 and 3 (each within the scatter of the next); then compound 1.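

Within the data shown here, on the carbonyl carbon, benzylamino, the first group here joined through nitrogen, stays level with the larger esters, with a number 7 percentage points lower from compound 3 to compound 4 (within the scatter) and a number 5 percentage points lower from compound 2 to compound 4 (within the scatter). Against the ethoxy group, the gap remains, with a number 57 percentage points lower from compound 1 to compound 4 (beyond the scatter), so among these compounds, only compound 1 stands apart in this assay. Nothing available here accounts for this result.

From the compounds shown here alone, it remains open whether the higher number of compound 1 is particular to ethoxy or would carry over to methoxy or ethylamino on the same carbonyl carbon. Going by these compounds, how a free carboxylic acid would behave there also remains open.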